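Moving from 4-chlorophenyl to 3-chloro-4-fluorophenyl

The compounds below may be only part of what the source reports. "The series", "measured", "known", "first", "only" and "open" are said of these compounds alone.

Of the compounds shown here, three sharing one core have been measured in an assay on HEK293 cells for displacement of a labelled ligand from Melanocortin receptor 4 (Homo sapiens); on this read-out lower numbers stand for stronger inhibition and higher numbers for weaker inhibition. Compound 3 `CC(C)[C@H](NC(=O)CCN(C)C)c1cccc(F)c1N1CCN(C(=O)[C@@H]2CN(C(C)C)C[C@H]2c2ccc(Cl)cc2)CC1` gives 5.3 nM in this assay and stands second lowest of the three numbers. Among the measured compounds shown here, compound 2 `Cc1ccc(N2CCN(C(=O)[C@@H]3CN(C4CCOCC4)C[C@H]3c3ccc(Cl)cc3)CC2)c([C@@H](NC(=O)CN)C(C)C)c1` gives 2 nM, the only lower value, and compound 1 `CC(C)[C@H](NC(=O)CCN(C)C)c1cccc(F)c1N1CCN(C(=O)[C@@H]2CN(C(C)C)C[C@H]2c2cc(F)c(F)c(F)c2)CC1` gives 250 nM, the highest. Compound 4 `CC(C)[C@H](NC(=O)CCN(C)C)c1cccc(F)c1N1CCN(C(=O)[C@@H]2CN(C(C)C)C[C@H]2c2ccc(F)c(Cl)c2)CC1` is not yet measured; it differs from compound 3 only in that (3-chloro-4-fluorophenyl in place of 4-chlorophenyl on a saturated ring carbon).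

For the measured compounds named here, the single measured step that bears on this aryl position is a 47-fold lower number from compound 1 to compound 3 (1.67 log units; beyond the scatter), a large change in which the 3,4,5-trifluorophenyl of compound 1 was exchanged for 4-chlorophenyl. Compound 4 keeps a chlorine on the ring but also carries a fluorine, and so sits between the two measured patterns. Since the trifluoro pattern of compound 1 gave 250 nM, a moderate rise in the number is expected for compound 4, but well short of that of compound 1. Compound 4 is therefore estimated at 15 nM, with a range from 4 nM to 60 nM, which is expected to mean a step of a 2.8-fold higher number from compound 3 to compound 4 (0.45 log units; beyond the scatter).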

Compound 4, inhibition constant: 260 nM
For compound 4 the middle estimate is 17-fold (1.24 log units) below the measured one; measured number above the stated range.
By their numbers in this assay, from the lowest: compound 2; then compound 3; then compounds 1 and 4 (each within the scatter of the next).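

In this assay, the exchange of 4-chlorophenyl for 3-chloro-4-fluorophenyl gives a 49-fold higher number from compound 3 to compound 4 (1.69 log units; beyond the scatter), which shows that this position can respond sharply even when the ring keeps its chlorine. The further step, a 1.0-fold higher number from compound 1 to compound 4 (0.02 log units; within the scatter), leaves the 3-chloro-4-fluorophenyl and 3,4,5-trifluorophenyl groups within the scatter of each other, so among compounds 1, 3 and 4, which differ only here, 4-chlorophenyl alone gives the low number. The data offer no measured explanation for this sensitivity.

What 3-chlorophenyl or 4-fluorophenyl would give at this position stays open, so the compounds shown do not separate the added fluorine from the changed place of the chlorine. Going by these compounds, whether the same sensitivity holds with the other substituents of compound 2 also remains open.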